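The source may report more compounds than this note shows. Statements on the series, on what has been measured and on what is new or still open speak of the compounds shown alone.

Measured so far:
compound 1, `COc1ccc(N2CCN(Cc3csc(N)c3C(=O)c3ccc(Cl)cc3)CC2)cc1`: 0%
compound 2, `Nc1scc(CN2CCN(c3ccc(OC(F)(F)F)cc3)CC2)c1C(=O)c1ccc(Cl)cc1`: 1%
compound 3, `Nc1scc(CN2CCN(c3ccc(F)cc3F)CC2)c1C(=O)c1ccc(Cl)cc1`: 0%

All three share one core and differ only in the aryl group on the amine nitrogen in the ring. In an assay on CHO cells for displacement of a labelled ligand from adenosine receptor A3 (Homo sapiens), read by scintillation counting, with a stated time of 120 min, tested at 10 uM (a lower number here means less inhibition, a higher number more inhibition at the concentration tested (going by the name of the read-out)), compound 3 stands level with compound 1 at the digits read, and compound 2 lies within the scatter of both: no change at the digits printed from compound 1 to compound 3 (within the scatter) and a number 1 percentage points lower from compound 2 to compound 3 (within the scatter). The third step, a number 1 percentage points higher from compound 1 to compound 2 (within the scatter), is likewise within the scatter, so none of the three aryl variants separates from the others in this assay.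

The next compound, compound 4, `Nc1scc(CN2CCN(c3ccc(Cl)c(Cl)c3)CC2)c1C(=O)c1ccc(Cl)cc1`, changes the same position again: 3,4-dichlorophenyl in place of 2,4-difluorophenyl on an amine nitrogen in a ring. Among the compounds with values here, every step so far that touches this aryl group has stayed within the scatter, so no step beyond the scatter is expected here either; the estimated step is a number 1 percentage points higher from compound 3 to compound 4 (within the scatter). On that basis compound 4 is expected to give 1% in this assay, with a range from -6% to 10%.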

Compound 4, a percentage reported as inhibition, at one concentration (the size of the read-out at that concentration, not a potency): 3%
Estimate against measurement, compound 4: 2 percentage points below; low and high end bracket the measured number.
By their numbers in this assay, from the lowest: compounds 1, 3, 2 and 4 (each within the scatter of the next).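

In this assay, chlorine on the aryl group, here as 3,4-dichlorophenyl with the same heavy-atom count as the 2,4-difluorophenyl it replaces, does not separate from the earlier aryl groups: a number 3 percentage points higher from compound 3 to compound 4 (within the scatter), a number 2 percentage points higher from compound 2 to compound 4 (within the scatter), and a number 3 percentage points higher from compound 1 to compound 4 (within the scatter). All four aryl groups on this amine nitrogen in a ring therefore remain within the scatter of one another, with methoxy, trifluoromethoxy, fluorine and chlorine substituents all tested there. Nothing available gives a reason for this result.

Still open, from the compounds shown here alone, is whether a non-aryl group on this nitrogen, such as benzyl or acetyl, or a basic amine or carboxylic acid on the aryl ring, would separate from these four. Also open, going by these compounds, is whether replacing the 4-chlorophenyl ketone of the shared core would change the reading.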